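Carbamate versus Acyl on the Ring Nitrogen

The source may hold more compounds than are shown below. What is called first, only, known or untested is meant among the compounds shown, and "the series" means these compounds.

Compound 1, `COC(=O)C1=C(C(C)C)NC(=O)NC1c1cccc([N+](=O)[O-])c1`, in an assay on HEK293 cells for antagonist activity at Voltage-dependent L-type calcium channel subunit alpha-1D (Rattus norvegicus), read by FLIPR (on this read-out lower numbers stand for stronger inhibition and higher numbers for weaker inhibition), gives > 100000 nM, which is a limit of the assay.
Compound 2, `CCOC(=O)N1C(=O)NC(C(C)C)=C(C(=O)OC)C1c1cccc([N+](=O)[O-])c1`, gives 24500 nM.
Compound 3, `COC(=O)C1=C(C(C)C)NC(=O)N(C(=O)C(C)C)C1c1cccc([N+](=O)[O-])c1`, gives > 100000 nM, again a limit of the assay.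

Compound 3 therefore stands at the ceiling of this assay without a number of its own, a position it shares with one other value (the limit of > 100000 nM in this assay, at which 2 of the 3 values shown sit). Compound 4, `COC(=O)C1=C(C(C)C)NC(=O)N(C(=O)OC(C)C)C1c1cccc([N+](=O)[O-])c1`, differs from compound 3 by isopropoxy in place of isopropyl on a carbonyl carbon. Two measured steps speak to this change. From the ring amide hydrogen of compound 1, the ethoxycarbonyl gave an at least 4.0-fold lower number from compound 1 to compound 2 (0.61 log units; beyond the scatter), while the isopropylcarbonyl gave a step that the two limits leave unreadable from compound 1 to compound 3. More directly, the exchange of ethoxy for isopropyl on the carbonyl carbon produced an at least 4.0-fold higher number from compound 2 to compound 3 (0.61 log units; beyond the scatter), and the step to compound 4 returns an alkoxy group to that same carbonyl carbon. Since the forward exchange gave an at least 4.0-fold higher number from compound 2 to compound 3 (0.61 log units; beyond the scatter), compound 4 is expected to show an at least 3.3-fold lower number from compound 3 to compound 4 (0.52 log units; beyond the scatter). Compound 4 is thus estimated at 30000 nM, with a range from 8000 nM to 100000 nM, and a real chance remains that only a limit is returned.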

Compound 4, half-maximal inhibitory concentration: 10100 nM
Compound 4: the middle estimate sits 3.0-fold (0.47 log units) above what was measured, within the range that was stated.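

On the amide-type nitrogen in the ring, exchanging isopropyl for isopropoxy on the carbonyl carbon gives an at least 9.9-fold lower number from compound 3 to compound 4 (0.99 log units; beyond the scatter), so the contrast between alkoxy and alkyl seen earlier with ethoxy now also holds for a matched pair that differs only in the oxygen. Within the alkoxy series the group on the oxygen also counts, since the extra methyl of isopropoxy gives a 2.4-fold lower number from compound 2 to compound 4 (0.38 log units; beyond the scatter), which makes compound 4 the one with the lowest number of the four compounds shown. Isopropoxycarbonyl in place of the ring amide hydrogen gives an at least 9.9-fold lower number from compound 1 to compound 4 (0.99 log units; beyond the scatter), and this step and the one from compound 3 are lower bounds only, with one end of each resting on a limit of the assay: the limit of > 100000 nM in this assay, at which 2 of the 4 values shown sit.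

The compounds shown leave open whether a longer chain or a benzyl group on that oxygen would carry the trend from ethoxy to isopropoxy further. They also leave open whether an amine on the same carbonyl carbon, giving a urea, would behave like the alkoxy groups in compound 2 and compound 4 or like the isopropyl group in compound 3.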